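Swapping Nitro for Methoxy: Cytotoxicity Expected Unchanged

The compounds below may be only part of what the source reports. "The series", "measured", "known", "first", "only" and "open" are said of these compounds alone.

Of the compounds shown here, three sharing one core have been tested in an ADME assay on cells (Mus musculus, strain BALB/c) for cytotoxicity, read by MTT assay, with a stated time of 24 h; a lower number here means that less compound is tolerated, a higher number that more compound is tolerated. Compound 1 `COc1cc(-c2nnc(SCc3cccc([N+](=O)[O-])c3)o2)ccc1O` gives 392000 nM, standing second highest of the three and within the scatter of compound 3 `COc1cc(-c2nnc(SCc3ccccc3Br)o2)ccc1O` at 363000 nM and of compound 2 `COc1cc(-c2nnc(SCc3ccccc3F)o2)ccc1O` at 474000 nM. Going by the values given here, the one comparable step, a 1.3-fold lower number from compound 2 to compound 3 (0.12 log units; within the scatter), stays within the scatter. Compound 4 `COc1cccc(CSc2nnc(-c3ccc(O)c(OC)c3)o2)c1` differs from compound 1 by methoxy in place of nitro on an aromatic carbon. Among the compounds with values here, no measured step exchanges a nitro group for a methoxy group, so the only guidance is that the single change measured so far did not move this assay beyond the scatter. The expected step is therefore a 1.0-fold higher number from compound 1 to compound 4 (0.01 log units; within the scatter), nothing beyond the scatter. Compound 4 is estimated at 400000 nM, with a range from 250000 nM to 650000 nM.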

Compound 4, half-maximal cytotoxic concentration: 389000 nM
Compound 4: the middle estimate sits 1.0-fold (0.01 log units) above what was measured; measured number inside the range.
By their numbers in this assay, from the lowest: compounds 3, 4, 1 and 2 (each within the scatter of the next).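

In this assay the exchange of nitro for methoxy on an aromatic carbon, meta to a large group, is a 1.0-fold lower number from compound 1 to compound 4 (0.00 log units; within the scatter) and so stays within the scatter. Exchanging the whole ring substituent also leaves the number within the scatter, with a 1.1-fold higher number from compound 3 to compound 4 (0.03 log units; within the scatter) and a 1.2-fold lower number from compound 2 to compound 4 (0.09 log units; within the scatter) as the two steps. Nothing available explains why these changes leave the number in place. From the compounds shown here alone, whether an amine or a carboxylic acid at this position would move the number beyond the scatter remains open.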